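Moving Two Chlorines Around a Shared Core

This account rests on a few compounds, and the source may have more. Where it says the series, first, only, none or still open, it means among the compounds named here.

Measured in an assay on CHO cells for agonist activity at G protein-coupled receptor GPR35 (Rattus norvegicus), read by a beta-galactosidase reporter and beta-arrestin recruitment, with a stated time of 90 min; a higher number here means that more compound is needed for the effect, a lower number that less compound is needed:
Compound 1 `COc1ccc(C(=O)Nc2cc(F)cc3c(=O)cc(C(=O)O)oc23)cc1` gives 1760 nM.
Compound 2 `O=C(Nc1cc(F)cc2c(=O)cc(C(=O)O)oc12)c1ccc(Cl)c(Cl)c1` gives 2650 nM.

Compound 2 has the higher of these two numbers, yet the step of a 1.5-fold higher number from compound 1 to compound 2 (0.18 log units; within the scatter) stays within the scatter, so the two are not distinguishable. Compound 3 `O=C(O)c1cc(=O)c2cc(F)cc(NC(=O)c3cccc(Cl)c3Cl)c2o1` differs from compound 2 by 2,3-dichlorophenyl in place of 3,4-dichlorophenyl on a carbonyl carbon. Among the measured compounds shown here, the only measured step, a 1.5-fold higher number from compound 1 to compound 2 (0.18 log units; within the scatter), exchanged a whole group at that carbonyl carbon and was within scatter; nothing measured tests a shift of chlorines alone. A step no larger than the scatter, a 1.0-fold lower number from compound 2 to compound 3 (0.01 log units; within the scatter), is therefore expected. The estimate for compound 3 in this assay is 2600 nM, ranging from 900 nM to 8000 nM.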

Compound 3, half-maximal effective concentration: 3130 nM
For compound 3 the middle estimate is 1.2-fold (0.08 log units) below the measured one; the range from low to high includes it.
By their numbers in this assay, from the lowest: compounds 1, 2 and 3 (each within the scatter of the next).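

The shift of chlorines alone gives a 1.2-fold higher number from compound 2 to compound 3 (0.07 log units; within the scatter) in this assay and so shows that 3,4-dichlorophenyl and 2,3-dichlorophenyl on this carbonyl carbon cannot be told apart here. Exchanging the whole group gives a 1.8-fold higher number from compound 1 to compound 3 (0.25 log units; within the scatter) and also stays inside the scatter, so 4-methoxyphenyl and both dichlorophenyl groups are indistinguishable at this position. No measurement available here explains this lack of separation.

From the compounds shown here alone, whether any group at this carbonyl carbon can move the number beyond the scatter remains open. A simple phenyl without chlorines, or a chain carrying an amine in place of the aromatic ring, would be a direct test.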